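The source may report more compounds than this note shows. Statements on the series, on what has been measured and on what is new or still open speak of the compounds shown alone.

Measured compounds: compound 1 `COc1cc(Cl)cc(-c2nn(-c3cccc(NC(=O)Nc4ccc(Cl)c(Cl)c4)c3)cc2-c2ccncc2)c1` and compound 2 `COc1cc(Cl)cc(-c2nn(-c3cccc(NC(=O)c4cccc(C(F)(F)F)c4)c3)cc2-c2ccncc2)c1`.

In a functional assay on HOP-62 cells (Homo sapiens) for inhibition, read by sulforhodamine B assay, with a stated time of 48 h, tested at 10 uM (a lower number here means a stronger effect, a higher number a weaker effect of the compound at the concentration tested), compound 1 gives 15.7%. In this assay, going by the values given here, compound 2 gives 71.6%, the highest of the two numbers; its only neighbour is compound 1 (a number 55.9 percentage points higher from compound 1 to compound 2 (beyond the scatter)). Compound 3 `COc1cc(Cl)cc(-c2nn(-c3cccc(NC(=O)c4cc(C(F)(F)F)cc(C(F)(F)F)c4)c3)cc2-c2ccncc2)c1` differs from compound 2 by trifluoromethyl in place of hydrogen on an aromatic carbon. Among the compounds with values here, the one measured step replaced the whole amide substituent, a far larger change than the added trifluoromethyl here, so it bears only loosely on this step. A step from compound 2 to compound 3 within the scatter is expected (a number 2.4 percentage points higher from compound 2 to compound 3 (within the scatter)). Compound 3 is estimated at 74%, between 52% and 96%.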

Compound 3, a percentage reported as activity, at one concentration (the size of the read-out at that concentration, not a potency): 103%
The estimate for compound 3 lay 29 percentage points below the measured number; measured number outside the range, above it.
By their numbers in this assay, from the lowest: compound 1; then compound 2; then compound 3.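

In this assay, adding a single trifluoromethyl to the aromatic ring of the amide, meta to the existing trifluoromethyl group, gives a number 31.4 percentage points higher from compound 2 to compound 3 (beyond the scatter) and so a weaker effect at the concentration tested. This aromatic carbon is therefore not a neutral place: a change of one group here moves the number beyond the scatter, whereas the earlier step had replaced the whole amide substituent.

From the compounds shown here alone, whether a methyl group or an amine at this place would move the number in the same direction remains open. What lies behind the shift also remains open, as no measurement at hand bears on it.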